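Swapping tert-butyl for nitro: a small step expected

The source may hold more compounds than are shown below. What is called first, only, known or untested is meant among the compounds shown, and "the series" means these compounds.

Measured so far in a functional assay on Hep 3B2 cells (Homo sapiens) for cytotoxicity, read by MTT assay, with a stated time of 6 days (a higher number here means a weaker inhibitor, a lower number a stronger inhibitor), are three compounds:
- Compound 1 `CCCC1Oc2ccccc2N(Cc2cn(Cc3ccccc3)nn2)C1=O` gives 61800 nM
- Compound 2 `O=C1COc2cccnc2N1Cc1cn(Cc2ccccc2)nn1` gives 8700 nM
- Compound 3 `CC(C)(C)c1ccc(Cn2cc(CN3C(=O)COc4ccccc43)nn2)cc1` gives 25600 nM

Compound 3 stands second highest of the three, at 25600 nM in the middle of the series. Compound 1 lies above it and compound 2 below it, and both gaps are beyond the usual scatter.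

The next compound to be tested is compound 4 `O=C1COc2ccccc2N1Cc1cn(Cc2ccc([N+](=O)[O-])cc2)nn1`. It carries nitro in place of tert-butyl on an aromatic carbon, para to a large group (nitro in place of tert-butyl on an aromatic carbon). Going by the values given here, no pair of measured compounds differs in only one place, so the data show nothing directly about this kind of change. The expectation therefore rests on the spread of the series, and compound 3 at 25600 nM is the natural starting point. In this assay the step is expected to stay within the scatter, leaning slightly towards a lower number, and the estimate is a 1.3-fold lower number from compound 3 to compound 4 (0.11 log units; within the scatter) for this small change. Compound 4 is estimated at 20000 nM with a range from 6000 nM to 60000 nM expected.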

Compound 4, half-maximal inhibitory concentration: 29600 nM
For compound 4 the middle estimate is 1.5-fold (0.17 log units) below the measured one; low and high end bracket the measured number.
By their numbers in this assay, from the lowest: compound 2; then compounds 3 and 4 (each within the scatter of the next); then compound 1.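

In this assay, going by these compounds alone, the exchange of tert-butyl for nitro on an aromatic carbon, para to a large group, gives a 1.2-fold higher number from compound 3 to compound 4 (0.06 log units; within the scatter) and so provides the first direct reading of a single change. At this place, the read-out does not separate an all-carbon group without hydrogen-bond acceptors from a group of nitrogen and oxygen that brings hydrogen-bond acceptors, so this pair shows no sign that the difference between these two groups matters in this assay. No measurement at hand bears on why the two compounds read alike.

Still open, going by these compounds, is how an amine, a carboxylic acid or a simple hydrogen at this same place would read, since one exchange between two groups cannot show whether the position tolerates change in general. On these data alone, it also remains unknown whether the same exchange would behave alike on the shared frameworks of compound 1 or compound 2, which each differ from compound 3 and compound 4 in more than one place.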